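Compound 4: methyl to hydrogen on the aromatic ring

The source may report more compounds than this note shows. Statements on the series, on what has been measured and on what is new or still open speak of the compounds shown alone.

Compound 3 `Cc1ccc(-c2csc(=N)n2CC(=O)N2CCN(C)CC2)cc1` gives 17100 nM in an assay on isolated protein for inhibition of vitamin D3 receptor (Homo sapiens) (a higher number here means a weaker inhibitor, a lower number a stronger inhibitor), the second highest of the three numbers measured. For the measured compounds named here, compound 1 `Cc1ccc(-c2csc(=N)n2CC(=O)N2CCN(c3ccccc3)CC2)cc1` gives 1030 nM, and the only single-point step measured, a 17-fold higher number from compound 1 to compound 3 (1.22 log units; beyond the scatter), concerns the ring amine nitrogen rather than the aromatic ring. Compound 2 `N=c1scc(-c2ccccc2)n1CC(=O)N1CCOCC1` gives 24400 nM, which lies within the scatter of compound 3, but compound 2 differs from compound 3 in two places, so no single step can be read from that pair. Compound 4 `CN1CCN(C(=O)Cn2c(-c3ccccc3)csc2=N)CC1` differs from compound 3 by hydrogen in place of methyl on an aromatic carbon. Going by the values given here, no measured step bears on this change. With nothing in the data pointing either way, the step expected in this assay is a 1.0-fold lower number from compound 3 to compound 4 (0.00 log units; within the scatter), none beyond the scatter. Compound 4 is estimated at 17000 nM, with a range of 6000 nM to 48000 nM.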

Compound 4, inhibition constant: 28300 nM
Compound 4: the middle estimate sits 1.7-fold (0.22 log units) below what was measured; the measured number falls inside the stated range.
By their numbers in this assay, from the lowest: compound 1; then compounds 3, 2 and 4 (each within the scatter of the next).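

In this assay, 4-methylphenyl to phenyl gives a 1.7-fold higher number from compound 3 to compound 4 (0.22 log units; within the scatter) with the methyl-bearing piperazine amide in place, so this position shows no readable effect of the methyl group here. For the compounds shown here, the first step at the carbonyl carbon, 4-methylpiperazin-1-yl in place of morpholin-4-yl, gives a 1.2-fold higher number from compound 2 to compound 4 (0.06 log units; within the scatter) and likewise separates nothing. Nothing available explains either step.

From the compounds shown here alone, it remains open whether losing the methyl reads the same with the phenyl on the ring amine nitrogen of compound 1. A chloro or methoxy group on the aromatic carbon is also untested among the compounds shown.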